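A few compounds are considered here, and "the series" means these few. Any claim that something is new, unique, unknown or untested is made for them only; others in the source may bear on it.

Working notes on the series. Compound 1 `CCOc1ccc(-c2cccc(C)c2)cc1` and compound 2 `CCOc1ccc(-c2cccc(C(=O)OCC(F)(F)F)c2)cc1` share one core and differ only in the group on the second ring. In an assay on COS-7 cells for inhibition of patatin-like phospholipase domain-containing protein 2 (Mus musculus) (a higher number here means a weaker inhibitor, a lower number a stronger inhibitor), compound 1 gives 70000 nM. In this assay compound 2 gives 120000 nM, the higher of the two numbers, though the two values lie within the scatter of each other. Compound 3 `CCNC(=O)c1cccc(-c2ccc(OCC)cc2)c1` is the ester carried into an amide: ethylamino in place of 2,2,2-trifluoroethoxy on a carbonyl carbon. Within the data shown here, no step between measured compounds covers such a change, and the two values at hand sit close together, so no step beyond the scatter is expected from compound 2 to compound 3 in this assay; the estimated step is a 1.5-fold lower number from compound 2 to compound 3 (0.18 log units; within the scatter). Compound 3 is estimated at 80000 nM, in the range 25000 nM to 250000 nM.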

Compound 3, half-maximal inhibitory concentration: 90000 nM
Estimate against measurement, compound 3: 1.1-fold (0.05 log units) below; low and high end bracket the measured number.
By their numbers in this assay, from the lowest: compounds 1, 3 and 2 (each within the scatter of the next).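

In this assay, ethylamino in place of 2,2,2-trifluoroethoxy on a carbonyl carbon gives a 1.3-fold lower number from compound 2 to compound 3 (0.12 log units; within the scatter), so the amide and the ester are not separated at this position. Ethylcarbamoyl in place of methyl on an aromatic carbon gives a 1.3-fold higher number from compound 1 to compound 3 (0.11 log units; within the scatter), so all three groups on the second ring read alike in this assay. Nothing at hand bears on why these values stay together. Still open, as far as these compounds go, is whether any group here gives a step beyond the scatter, such as a carboxylic acid, an amine or a longer chain on the amide nitrogen.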